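Side-chain nitrile and cytotoxicity: next amine variant

The source may hold more compounds than are shown below. What is called first, only, known or untested is meant among the compounds shown, and "the series" means these compounds.

In an ADME assay on MT4 cells (Homo sapiens) for cytotoxicity, read by MTT assay, with a stated time of 5 days (on this read-out lower numbers stand for higher toxicity in this test and higher numbers for lower toxicity in this test), compound 1 `COCCNc1cc(Oc2c(C)cc(/C=C/C#N)cc2C)nc(Nc2ccc(C#N)cc2)n1` gives 3190 nM and compound 2 `COC(Nc1cc(Oc2c(C)cc(/C=C/C#N)cc2C)nc(Nc2ccc(C#N)cc2)n1)OC` gives 3470 nM, with a 1.1-fold higher number from compound 1 to compound 2 (0.04 log units; within the scatter), within the scatter. Compound 3 `Cc1cc(/C=C/C#N)cc(C)c1Oc1cc(NCCC#N)nc(Nc2ccc(C#N)cc2)n1` stands lowest of the three at 1000 nM. Compound 4 `Cc1cc(/C=C/C#N)cc(C)c1Oc1cc(NCC2CCCO2)nc(Nc2ccc(C#N)cc2)n1` has not yet been measured. It differs from compound 3 by oxolan-2-yl in place of cyanomethyl on a saturated chain carbon bound to a nitrogen on an aromatic ring. The relevant steps are a 3.2-fold lower number from compound 1 to compound 3 (0.50 log units; beyond the scatter) and a 3.5-fold lower number from compound 2 to compound 3 (0.54 log units; beyond the scatter), both modest and beyond the scatter. Compound 4 also loses the cyanomethyl end, so those two steps, read backwards, suggest a similar modest rise, though no ring-bearing chain has been measured. The expected change is a 2.8-fold higher number from compound 3 to compound 4 (0.45 log units; beyond the scatter). For compound 4 the estimate is 2800 nM, with an expected range of 1100 nM to 7500 nM.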

Compound 4, half-maximal cytotoxic concentration: > 268000 nM
Compound 4 ended at the assay's limit; the forecaster's own chance of this, stated with the estimate: 10%; middle value at least 95-fold (1.98 log units) from the limit.
By their numbers in this assay, from the lowest: compound 3; then compounds 1 and 2 (each within the scatter of the next). At a limit, above all of these: compound 4.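

In this assay compound 4 gives a limit and not a number: the limit of > 268000 nM in this assay, at which 1 of the 4 values shown sits. Earlier changes on this chain moved the read-out only modestly, whereas the ring-bearing end gives an at least 260-fold higher number from compound 3 to compound 4 (2.42 log units; beyond the scatter), along with an at least 77-fold higher number from compound 2 to compound 4 (1.88 log units; beyond the scatter) and an at least 84-fold higher number from compound 1 to compound 4 (1.92 log units; beyond the scatter). Among the compounds shown, (oxolan-2-yl)methyl on the nitrogen thus stands apart from all three open-chain substituents, and the full size of each step remains unknown.

As far as these compounds go, whether this separation needs the ring oxygen or only the ring remains open. A cyclopentylmethyl group at this place would distinguish the two.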